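The source may report more compounds than this note shows. Statements on the series, on what has been measured and on what is new or still open speak of the compounds shown alone.

Compound 1, whose structure is `CCC1=C(O)c2c(oc(-c3ccc(CC(C)C)cc3)cc2=O)C(CC)(CC)C1=O`, is the starting point of this comparison. Going by the values given here, in a functional assay on KBVIN cells (Homo sapiens) for antiproliferative activity, read by sulforhodamine B assay, with a stated time of 3 days (on this read-out higher numbers stand for an effect only at larger amounts of compound and lower numbers for an effect already at smaller amounts), compound 1 gives 17.4 uM, the highest of the three numbers measured so far. Its two neighbours both carry an oxygen-bearing group on the aromatic ring in place of the isobutyl: compound 2, with structure `CCOc1ccc(-c2cc(=O)c3c(o2)C(CC)(CC)C(=O)C(CC)=C3O)cc1`, gives 7.54 uM in this assay, and compound 3, with structure `CCC1=C(O)c2c(oc(-c3ccc(OC(F)(F)F)cc3)cc2=O)C(CC)(CC)C1=O`, gives 9.95 uM. Measured as steps, these are a 2.3-fold lower number from compound 1 to compound 2 (0.36 log units; beyond the scatter) and a 1.7-fold lower number from compound 1 to compound 3 (0.24 log units; within the scatter).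

Compound 4, with structure `CCC1=C(O)c2c(oc(-c3ccc(COC)cc3)cc2=O)C(CC)(CC)C1=O`, has not yet been measured. Compared with compound 1, the change is methoxy in place of isopropyl on a saturated chain carbon bound to an aromatic carbon; cut one bond further out, it reads as isobutyl to methoxymethyl. So, as in compounds 2 and 3, an oxygen enters the substituent on the aromatic ring, though here a saturated chain carbon remains between the ring and the oxygen. The two steps that bear on it both lowered the number, one beyond the scatter and one within it, so a small lowering, at most modest, is expected here, namely a 1.6-fold lower number from compound 1 to compound 4 (0.20 log units; within the scatter). The estimate for compound 4 in this assay is therefore 11 uM, with a range from 5 uM to 25 uM.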

Compound 4, concentration for half-maximal effect: 3.4 uM
Compound 4: the middle estimate sits 3.2-fold (0.51 log units) above what was measured; the measured number lies below the stated range.
By their numbers in this assay, from the lowest: compound 4; then compounds 2, 3 and 1 (each within the scatter of the next, the first and the last beyond it).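

The step of a 5.1-fold lower number from compound 1 to compound 4 (0.71 log units; beyond the scatter) is the largest in this set and gives compound 4 the lowest number in this assay, so this position tolerates the change and the effect appears at smaller amounts of compound. Compound 4 also stands clear of both oxygen-bearing neighbours, through a 2.9-fold lower number from compound 3 to compound 4 (0.47 log units; beyond the scatter) and through a 2.2-fold lower number from compound 2 to compound 4 (0.35 log units; beyond the scatter) as well, although those two neighbours lie within the scatter of each other. An oxygen in the substituent is therefore not enough to set the size of the step, since the methoxymethyl of compound 4 does more than the ethoxy or trifluoromethoxy placed directly on the aromatic carbon, and no measurement available here accounts for that difference.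

As far as these compounds go, it remains open whether the oxygen of the methoxy itself matters or whether the shorter group alone would do, which a dimethylamino group or a longer chain such as ethoxy on the same saturated chain carbon could help separate. A hydroxy group at this place, which would leave the chain carbon but drop the methyl, is also absent from the compounds shown, so how far the gain extends stays unknown.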